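The source may hold more compounds than are shown below. What is called first, only, known or untested is meant among the compounds shown, and "the series" means these compounds.

Compound 2, with the structure `COC(OC)C1=C(C(=O)OC/C=C/c2ccc(C(F)(F)F)cc2)C(c2cccc(Cl)c2)C(C(=O)O)=C(C)N1`, gives 3200 nM in an assay on thoracic aorta for inhibition of Voltage-gated L-type calcium channel (Rattus norvegicus) (a higher number here means a weaker inhibitor, a lower number a stronger inhibitor), which places it at the higher end of the two numbers recorded so far. Among the compounds with values here, its closest neighbour is compound 1, with the structure `COC(OC)C1=C(C(=O)OC/C=C/c2ccc(Cl)cc2)C(c2cccc(Cl)c2)C(C(=O)O)=C(C)N1`, which in this assay gives 1400 nM; the step of a 2.3-fold higher number from compound 1 to compound 2 (0.36 log units; beyond the scatter) is the only measured step in this set.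

Compound 3, with the structure `COc1ccccc1/C=C/COC(=O)C1=C(C(OC)OC)NC(C)=C(C(=O)O)C1c1cccc(Cl)c1`, differs from compound 2 by the change (2-methoxyphenyl in place of 4-(trifluoromethyl)phenyl on a double-bonded chain carbon bound to a double-bonded chain carbon). Within the data shown here, no measured step covers this exchange directly: the one known step concerns chloro against trifluoromethyl on the same aromatic carbon, and it was modest in size. That step shows that the group on this aromatic ring can shift the number by a modest amount in either direction, but nothing measured tells whether methoxy at the new position lands nearer compound 1 or compound 2. The estimate for compound 3 in this assay is therefore 2000 nM, within a range from 700 nM to 6000 nM, corresponding to an expected step of a 1.6-fold lower number from compound 2 to compound 3 (0.20 log units; within the scatter) that may well stay within the scatter.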

Compound 3, half-maximal inhibitory concentration: 5900 nM
Estimate against measurement, compound 3: 3.0-fold (0.47 log units) below; the range from low to high includes it.
By their numbers in this assay, from the lowest: compound 1; then compounds 2 and 3 (each within the scatter of the next).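

In this assay, putting 2-methoxyphenyl where 4-(trifluoromethyl)phenyl stood gives a 1.8-fold higher number from compound 2 to compound 3 (0.27 log units; within the scatter), so this assay does not tell these two aryl groups apart, although they carry different substituents at different ring positions. The exchange of 4-chlorophenyl for 2-methoxyphenyl at the same place gives a 4.2-fold higher number from compound 1 to compound 3 (0.62 log units; beyond the scatter), which is beyond the scatter and modest in size, so among the three compounds shown, compound 1 stands apart from both of the others, and the 4-chlorophenyl group gives the lowest number at this place. No measurement here offers an explanation for this separation of compound 1 from the other two.

The compounds shown leave open whether the gap between compound 1 and compound 3 follows from exchanging chloro for methoxy or from the different ring position, as 4-chlorophenyl and 2-methoxyphenyl differ in both. Also open, from the compounds shown here alone, is how this assay would respond to an unsubstituted phenyl ring, or to an amine or a carboxylic acid on the ring, at this same place.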